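This account rests on a few compounds, and the source may have more. Where it says the series, first, only, none or still open, it means among the compounds named here.

Compound 1 `COc1ccc(C(=O)Nc2cc3nc(C4CCCCC4)[nH]c3cc2N(C)C)cc1` and compound 2 `CN(C)c1cc2[nH]c(C3CCCCC3)nc2cc1NC(=O)c1ccc(OC(F)F)cc1` share the same core and differ in a single group, difluoromethyl in place of methyl on an oxygen on an aromatic ring. In an ADME assay on Vero cells (Chlorocebus sabaeus) for cytotoxicity, read by resazurin assay, with a stated time of 3 days (on this read-out lower numbers stand for stronger inhibition and higher numbers for weaker inhibition), compound 1 gives only a limit of the assay, > 100 ug/mL. In this assay compound 2 also gives only a limit, > 100 ug/mL. The step that the two limits leave unreadable from compound 1 to compound 2 therefore has no readable size or direction because both readings sit at the limit of > 100 ug/mL in this assay, at which 2 of the 2 values shown sit.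

Compound 3 `CN(C)c1cc2[nH]c(C3CCCCC3)nc2cc1NC(=O)OCc1ccccc1` has not yet been measured in this assay. It differs from compound 2 by benzyloxy in place of 4-(difluoromethoxy)phenyl on a carbonyl carbon. Among the compounds with values here, the one measured step concerns a different part of the molecule and is itself unreadable, so it offers no ground for expecting a change beyond the scatter in this assay, and the starting point for compound 2 is a limit rather than a number. The step expected from this change is a step that the limit leaves unreadable from compound 2 to compound 3, which is no movement beyond the scatter. Compound 3 is accordingly estimated at 150 ug/mL, with a range from 40 ug/mL to 500 ug/mL, most likely reported again only as a limit.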

Compound 3, half-maximal inhibitory concentration: > 100 ug/mL
Compound 3 ended at the assay's limit; the forecaster's own chance of this, stated with the estimate: 75%; the middle value lies beyond the limit too.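

In this assay compound 3 gives > 100 ug/mL, which is a limit of the assay and not a number. No step among compound 1, compound 2 and compound 3 can be read: the limit of > 100 ug/mL in this assay, at which 3 of the 3 values shown sit.

The compounds shown leave open whether changing the group on the carbonyl carbon alters the actual cytotoxicity value in this assay at all.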